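A Phenoxy Group in Place of Bromo

The compounds below may be only part of what the source reports. "The series", "measured", "known", "first", "only" and "open" are said of these compounds alone.

Measured in a functional assay on cells (Erythrocyte, Homo sapiens) for inhibition, read by spectrophotometry and hemolysis, with a stated time of 10 min; on this read-out lower numbers stand for stronger inhibition and higher numbers for weaker inhibition:
- compound 1 (`Cc1cccc2nc(N/N=C\c3ccc([N+](=O)[O-])cc3)sc12`) gives 24.1 ug/mL
- compound 2 (`Cc1cccc2nc(N/N=C\c3ccc(Br)cc3)sc12`) gives 20.1 ug/mL

On these two numbers, compound 2 stands level with compound 1. Going by the values given here, the only measured step is a 1.2-fold lower number from compound 1 to compound 2 (0.08 log units; within the scatter) and it stays within the scatter of the measurement.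

The next compound is compound 3 (`Cc1cccc2nc(N/N=C\c3ccc(Oc4ccccc4)cc3)sc12`), which keeps the shared core but carries phenoxy in place of bromo on an aromatic carbon. The change is counted as phenoxy in place of bromo on an aromatic carbon and it adds a whole aromatic ring where a single atom stood. Among the compounds with values here, the measured step also exchanged one group on an aromatic carbon, so it is the only guide, but a weak one. Within the data shown here, no measured compound yet carries a second ring of this kind, and the data give no direction for such a change. The expected change is a 1.0-fold lower number from compound 2 to compound 3 (0.00 log units; within the scatter) and no shift beyond the scatter is therefore expected. The estimate for compound 3 is 20 ug/mL with an expected range from 9 ug/mL to 42 ug/mL in this assay.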

Compound 3, half-maximal inhibitory concentration: 60.9 ug/mL
For compound 3 the middle estimate is 3.0-fold (0.48 log units) below the measured one, outside the stated range (above it).
By their numbers in this assay, from the lowest: compounds 2 and 1 (each within the scatter of the next); then compound 3.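

The exchange of nitro for bromo had left this position looking indifferent, but it does not tolerate every group: in this assay the step to phenoxy on the same aromatic carbon gives a 3.0-fold higher number from compound 2 to compound 3 (0.48 log units; beyond the scatter) and, measured against the nitro compound, a 2.5-fold higher number from compound 1 to compound 3 (0.40 log units; beyond the scatter) as well. Going by these compounds alone, both steps lie beyond the scatter and point the same way, so the group that puts a whole six-membered aromatic ring and an oxygen where a single atom or a nitro group stood is the first change here to weaken inhibition, though only modestly. Nothing among the data shown explains why the number rises at this position.

The compounds shown leave open whether the rise belongs to the added ring, to the oxygen that links it, or simply to the larger number of heavy atoms, and a phenyl or benzyl group on this carbon would begin to separate these readings. They also leave open how methoxy, an amine or a carboxylic acid would fare here, and so whether any group at this carbon can take the number below that of compounds 1 and 2.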